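Cyclohexyl in Place of Phenyl on a Chemokine Receptor Antagonist

The source may report more compounds than this note shows. Statements on the series, on what has been measured and on what is new or still open speak of the compounds shown alone.

Measured so far in a functional assay on cells for antagonist activity at C-X-C chemokine receptor type 4 (Homo sapiens), read by fluorescence and calcium flux, with stated times of 25 min and 90 s; a higher number here means a weaker inhibitor, a lower number a stronger inhibitor:
compound 1, `c1ccc2c(c1)CN[C@@H](CN(CCCCNCc1ccncc1)[C@H]1CCCc3cccnc31)C2`, gives 22.7 nM
compound 2, `c1ccc(CNCCCCN(C[C@H]2Cc3ccccc3CN2)[C@H]2CCCc3cccnc32)cc1`, gives 20.1 nM

Compound 2 gives the lowest of the two numbers, but its nearest neighbour, compound 1, lies within the scatter of it, so the two cannot be ordered. For the measured compounds named here, the one measured step, a 1.1-fold lower number from compound 1 to compound 2 (0.05 log units; within the scatter), concerns a change at the same place as the one now considered and came out flat.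

Compound 3, `c1ccc2c(c1)CN[C@@H](CN(CCCCNCC1CCCCC1)[C@H]1CCCc3cccnc31)C2`, carries the change (cyclohexyl in place of phenyl on a saturated chain carbon bound to an amine nitrogen). Going by the values given here, the single step bearing on it, the exchange of pyridin-4-yl for phenyl, was within the scatter, so no sign of the direction a further swap at this carbon might take is available. The expected outcome for compound 3 is therefore a step of a 1.2-fold higher number from compound 2 to compound 3 (0.09 log units; within the scatter), no larger than the scatter. Compound 3 is estimated at 25 nM, with a range from 8 nM to 80 nM.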

Compound 3, half-maximal inhibitory concentration: 158 nM
The estimate for compound 3 lay 6.3-fold (0.80 log units) below the measured number; measured number outside the range, above it.
By their numbers in this assay, from the lowest: compounds 2 and 1 (each within the scatter of the next); then compound 3.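

In this assay, the group on this saturated chain carbon bound to an amine nitrogen proves not to be indifferent: cyclohexyl in place of phenyl gives a 7.9-fold higher number from compound 2 to compound 3 (0.90 log units; beyond the scatter), and cyclohexyl in place of pyridin-4-yl gives a 7.0-fold higher number from compound 1 to compound 3 (0.84 log units; beyond the scatter). The earlier step had not separated the two aromatic groups, whereas the non-aromatic ring of carbon only, with the same count of heavy atoms as phenyl, now stands apart from both, a division that holds for these three compounds alone. Nothing available explains why the number rises with cyclohexyl.

As far as these compounds go, whether a piperidin-4-yl ring or an open hexyl chain at this place would track cyclohexyl or the aromatic groups remains open. So does whether a smaller ring such as cyclopentyl would behave like cyclohexyl.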